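Benzotriazole amides against alpha amylase: methoxy to butoxy

The source may hold more compounds than are shown below. What is called first, only, known or untested is meant among the compounds shown, and "the series" means these compounds.

Compounds measured so far:
compound 1, `Cc1cc2nnn(C(=O)c3ccccc3)c2cc1C` — 3320 nM
compound 2, `Cc1ccc(C(=O)n2nnc3cc(Cl)c(Cl)cc32)cc1C` — 3660 nM
compound 3, `COc1ccc(C(=O)n2nnc3ccccc32)cc1` — 2980 nM

All three numbers come from an assay for inhibition of Alpha amylase (Homo sapiens), with a stated time of 10 min (on this read-out higher numbers stand for weaker inhibition and lower numbers for stronger inhibition), and sit within the scatter of one another. Compound 3 gives 2980 nM in this assay and stands at the low end of the three, but neither compound 1 nor compound 2 is separated from it by more than the scatter, so no ranking among them is supported.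

Compound 4, `CCCCOc1ccc(C(=O)n2nnc3ccccc32)cc1`, is not yet measured. It differs from compound 3 by propyl in place of hydrogen on a saturated chain carbon bound to an oxygen on an aromatic ring; cut one bond further out, the change reads methoxy to butoxy. Among the compounds with values here, no pair of measured compounds shows a change of this kind, so there is nothing from which a direction can be read. The working expectation is no step beyond the scatter: compound 4 is estimated at 2500 nM, with a range from 1000 nM to 6500 nM. The estimated step from compound 3 to compound 4 is a 1.2-fold lower number from compound 3 to compound 4 (0.08 log units; within the scatter), to be checked against the measurement.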

Compound 4, half-maximal inhibitory concentration: 5400 nM
Compound 4: the middle estimate sits 2.2-fold (0.33 log units) below what was measured; the range from low to high includes it.
By their numbers in this assay, from the lowest: compounds 3, 1, 2 and 4 (each within the scatter of the next).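

In this assay the series now has its first pair differing in one place, and methoxy to butoxy reads a 1.8-fold higher number from compound 3 to compound 4 (0.26 log units; within the scatter). Propyl in place of hydrogen on a saturated chain carbon bound to an oxygen on an aromatic ring therefore gives no step beyond the scatter here, and this single pair assigns neither a gain nor a loss to the butoxy chain. No measurement shown bears on the reason for this result.

The compounds shown leave open whether a longer chain such as hexyloxy, or an amine or a carboxylic acid at the end of the chain, would give a step beyond the scatter. Also open, as far as these compounds go, is whether methoxy to butoxy would read the same on the core of compound 1 or the core of compound 2.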